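Compound 4: 2-methoxyphenyl in place of 4-chlorophenyl

The source may hold more compounds than are shown below. What is called first, only, known or untested is meant among the compounds shown, and "the series" means these compounds.

In a functional assay on MDA-MB-231 cells (Homo sapiens) for antiproliferative activity, read by MTT assay, with a stated time of 48 h (on this read-out lower numbers stand for stronger inhibition and higher numbers for weaker inhibition), compound 1 (`CCS(=O)(=O)N1CCN(c2ncnc3sc(-c4ccc(N5CCN(C)CC5)cc4)cc23)CC1`) gives 7330 nM, compound 2 (`CN1CCN(c2ccc(-c3cc4c(N5CCN(C(=O)Nc6ccc(C#N)cc6)CC5)ncnc4s3)cc2)CC1`) gives 3930 nM and compound 3 (`CN1CCN(c2ccc(-c3cc4c(N5CCN(C(=O)Nc6ccc(Cl)cc6)CC5)ncnc4s3)cc2)CC1`) gives 5440 nM. Compound 3 thus stands within the scatter of both others. Compound 4 (`COc1ccccc1NC(=O)N1CCN(c2ncnc3sc(-c4ccc(N5CCN(C)CC5)cc4)cc23)CC1`) has 2-methoxyphenyl in place of 4-chlorophenyl on an amide-type nitrogen. The closest evidence is a 1.4-fold higher number from compound 2 to compound 3 (0.14 log units; within the scatter), a chloro in place of cyano. The exchanges on the ring amine nitrogen, a 1.9-fold lower number from compound 1 to compound 2 (0.27 log units; within the scatter) and a 1.3-fold lower number from compound 1 to compound 3 (0.13 log units; within the scatter), are equally small. Among the compounds with values here, no measured compound carries 2-methoxyphenyl, so no step beyond the scatter is expected, in either direction. The expected step is a 1.1-fold lower number from compound 3 to compound 4 (0.04 log units; within the scatter). For compound 4 the estimated value is 5000 nM, with a range of 2200 nM to 11000 nM.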

Compound 4, half-maximal inhibitory concentration: 23200 nM
Beside the measured number, compound 4's estimate is 4.6-fold (0.67 log units) below it; the measured number lies above the stated range.
By their numbers in this assay, from the lowest: compounds 2, 3 and 1 (each within the scatter of the next); then compound 4.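

In this assay, the aryl group on the amide-type nitrogen can move the number beyond the scatter, which chloro in place of cyano had not shown: 2-methoxyphenyl gives (a 4.3-fold higher number from compound 3 to compound 4 (0.63 log units; beyond the scatter)) against 4-chlorophenyl and (a 5.9-fold higher number from compound 2 to compound 4 (0.77 log units; beyond the scatter)) against 4-cyanophenyl. Exchange on the ring amine nitrogen now also leaves the scatter (a 3.2-fold higher number from compound 1 to compound 4 (0.50 log units; beyond the scatter)). Nothing measured here accounts for this rise.

As far as these compounds go, whether a plain phenyl on that nitrogen would sit with compound 2 and compound 3 or with compound 4 remains open, as does the result of an amine or a carboxylic acid on that aromatic ring.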